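The compounds below may be only part of what the source reports. "The series", "measured", "known", "first", "only" and "open" are said of these compounds alone.

In an ADME assay on L6 cells (Rattus norvegicus) for cytotoxicity, read by resazurin assay, with a stated time of 72 h (on this read-out higher numbers stand for weaker inhibition and lower numbers for stronger inhibition), compound 3 `OC(c1ccc(Cl)cc1)(c1cccnc1)c1cccs1` gives 67700 nM and compound 1 `OC(c1ccc(Cl)cc1)(c1cccnc1)c1ccccc1Cl` gives 61300 nM, two numbers within the scatter of each other. Compound 2 `OC(c1ccc(Cl)cc1)(c1cccnc1)c1ccccc1F` reads > 100000 nM, which is a limit of the assay. The next structure, compound 4 `OC(c1ccc(Cl)cc1)(c1cccnc1)c1nccs1`, differs from compound 3 by 1,3-thiazol-2-yl in place of thiophen-2-yl on a saturated chain carbon bound to two aromatic carbons and an oxygen on a saturated carbon, with 1,3-thiazol-2-yl in place of thiophen-2-yl on a saturated chain carbon bound to two aromatic carbons and an oxygen on a saturated carbon. Two measured changes at that same place bear on it: a 1.1-fold higher number from compound 1 to compound 3 (0.04 log units; within the scatter) and an at least 1.4-fold lower number from compound 2 to compound 3 (0.16 log units; that floor lies within the scatter), both within the scatter. In this assay no change beyond the scatter is therefore expected, only an estimated 1.2-fold higher number from compound 3 to compound 4 (0.07 log units; within the scatter). For compound 4 the estimated value is 80000 nM, with an expected range from 40000 nM to 130000 nM.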

Compound 4, half-maximal inhibitory concentration: > 100000 nM
Compound 4 gave a limit, no number; the forecaster's own chance of this, stated with the estimate: 35%; middle value at least 1.2-fold (0.09 log units) away from the limit.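

In this assay, 1,3-thiazol-2-yl joins 2-fluorophenyl as a group at this place whose compound reads as a limit, whereas thiophen-2-yl and 2-chlorophenyl gave numbers. The readable steps are an at least 1.4-fold higher number from compound 3 to compound 4 (0.16 log units; that floor lies within the scatter) and an at least 1.6-fold higher number from compound 1 to compound 4 (0.21 log units; that floor lies within the scatter), so neither establishes a change beyond the scatter, and the step between compound 2 and compound 4 cannot be read. The true size of these steps stays hidden because the readings stop at a limit: the limit of > 100000 nM in this assay, at which 2 of the 4 values shown sit.

From the compounds shown here alone, whether an amine or a carboxylic acid at this place would give a number rather than a limit stays open.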